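A few compounds are considered here, and "the series" means these few. Any claim that something is new, unique, unknown or untested is made for them only; others in the source may bear on it.

The measured compounds:
Compound 1, `Cc1ccc2nc(Nc3nc(Nc4ccc(S(N)(=O)=O)cc4)ncc3C)sc2c1`, 3280 nM
Compound 2, `Cc1cnc(Nc2ccc(S(N)(=O)=O)cc2)nc1Nc1nc2ccccc2s1`, 2800 nM
Compound 3, `CS(=O)(=O)c1ccc(Nc2nccc(Nc3nc4ccccc4s3)n2)cc1`, 11300 nM

All three were tested in a functional assay on HeLa cells (Homo sapiens) for antiproliferative activity, read by MTT assay, with a stated time of 48 h; on this read-out lower numbers stand for stronger inhibition and higher numbers for weaker inhibition. Compound 2 and compound 1 differ by methyl in place of hydrogen on an aromatic carbon, and this change gave a 1.2-fold higher number from compound 2 to compound 1 (0.07 log units; within the scatter). Compound 3 rests on a different core from compound 2; the difference between the two cores is not broken down here. In this assay compound 3 gives the highest of the three numbers.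

Compound 4, `Cc1ccc2nc(Nc3ccnc(Nc4ccc(S(C)(=O)=O)cc4)n3)sc2c1`, has not yet been measured. It differs from compound 3 by methyl in place of hydrogen on an aromatic carbon, the same change seen between compound 2 and compound 1, at a place described in the same words. Because a 1.2-fold higher number from compound 2 to compound 1 (0.07 log units; within the scatter) lay within the scatter, a similarly small shift is expected here. The expected step is a 1.1-fold higher number from compound 3 to compound 4 (0.04 log units; within the scatter). For compound 4 the estimated value in this assay is 12500 nM, likely between 5500 nM and 30000 nM.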

Compound 4, half-maximal inhibitory concentration: 2300 nM
For compound 4 the middle estimate is 5.4-fold (0.74 log units) above the measured one, and the stated range ends above it.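

Placing a methyl on the aromatic carbon of the fused ring system gave a 4.9-fold lower number from compound 3 to compound 4 (0.69 log units; beyond the scatter) in this assay, so this small change mattered on the core of compound 3. Set beside the earlier step, the same change did not carry over from one core to the other: the same change on two cores in this assay, a 1.2-fold higher number (0.07 log units; within the scatter) from compound 2 to compound 1 and a 4.9-fold lower number (0.69 log units; beyond the scatter) from compound 3 to compound 4, 5.8-fold (0.76 log units) apart, beyond the scatter of two such steps This shows that a result for this methyl cannot simply be transferred between these two cores, but two steps do not show which difference between the cores matters, or why.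

The compounds shown leave open whether a different group at this place, such as a chlorine atom, a methoxy group or an amine, would behave like the methyl. They also leave open how the methyl would behave on further cores.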